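One Change, Two Cores: What Compound 4 Should Give

The source may hold more compounds than are shown below. What is called first, only, known or untested is meant among the compounds shown, and "the series" means these compounds.

Of the compounds shown here, three have been measured in a functional assay on MOLT-3 cells (Homo sapiens) for cytotoxicity, read by XTT assay, with a stated time of 48 h; a higher number here means a weaker inhibitor, a lower number a stronger inhibitor. Compound 1 `COc1ccc(/C=C/C(=O)c2cccc(-n3cc(COc4ccc5ccc(=O)oc5c4)nn3)c2)c(OC)c1OC` gives 3890 nM. Compound 2 `COc1ccc(/C=C/C(=O)c2ccc(-n3cc(COc4ccc5ccc(=O)oc5c4)nn3)cc2)c(OC)c1OC` gives 22500 nM. Compound 3 `COc1ccc(/C=C/C(=O)c2cccc(-n3cc(COc4cc(=O)oc5ccccc45)nn3)c2)c(OC)c1OC` gives 1130 nM. Compound 2 has the highest number of the three; its nearest neighbour is compound 1, and compound 3 lies furthest from it, both gaps beyond the usual scatter.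

Compound 3 differs from compound 1 by a group of 11 heavy atoms (9 carbon, 2 oxygen; one six-membered aromatic ring of carbon only, one six-membered aromatic ring with 1 hetero atom) in place of a group of 11 heavy atoms (9 carbon, 2 oxygen; one six-membered aromatic ring of carbon only, one six-membered aromatic ring with 1 hetero atom), on an oxygen on a saturated carbon. That change produced a 3.4-fold lower number from compound 1 to compound 3 (0.54 log units; beyond the scatter).

Compound 1 and compound 2 are built from the same atoms joined differently; the difference between the two cores is not broken down here, and their two values alone show that compound 2 sits well above compound 1 in this assay.

Compound 4 `COc1ccc(/C=C/C(=O)c2ccc(-n3cc(COc4cc(=O)oc5ccccc45)nn3)cc2)c(OC)c1OC` has not yet been measured. It stands to compound 2 as compound 3 stands to compound 1: a group of 11 heavy atoms (9 carbon, 2 oxygen; one six-membered aromatic ring of carbon only, one six-membered aromatic ring with 1 hetero atom) in place of a group of 11 heavy atoms (9 carbon, 2 oxygen; one six-membered aromatic ring of carbon only, one six-membered aromatic ring with 1 hetero atom), on an oxygen on a saturated carbon. The place of the change is described in the same words in both pairs, so this is the same change, made on the core of compound 2 rather than on the core of compound 1.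

The expected step is a 3.2-fold lower number from compound 2 to compound 4 (0.51 log units; beyond the scatter), set beside the measured 3.4-fold lower number from compound 1 to compound 3 (0.54 log units; beyond the scatter). This expectation rests on a single measured pair, because compound 1 to compound 3 moved by a 3.4-fold lower number from compound 1 to compound 3 (0.54 log units; beyond the scatter) and nothing else tells how the change behaves on the second core, so the range is kept wide. Compound 4 is estimated at 7000 nM, expected to fall between 3000 nM and 18000 nM in this assay.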

Compound 4, half-maximal inhibitory concentration: 12300 nM
Compound 4: middle estimate off by 1.8-fold (0.24 log units), on the low side; measured number inside the range.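

In this assay, the exchange of one 11-heavy-atom group for the other, on an oxygen on a saturated carbon, can now be read on two cores, and the two readings do not differ: the same change on two cores in this assay, a 3.4-fold lower number (0.54 log units; beyond the scatter) from compound 1 to compound 3 and a 1.8-fold lower number (0.26 log units; within the scatter) from compound 2 to compound 4, 1.9-fold (0.27 log units) apart, within the scatter of two such steps

Taken alone, the new step of a 1.8-fold lower number from compound 2 to compound 4 (0.26 log units; within the scatter) cannot be told apart from no change on that core, whereas a 3.4-fold lower number from compound 1 to compound 3 (0.54 log units; beyond the scatter) stands clear of the scatter, so the exchange has a readable effect on only one of the two cores. The agreement between the steps therefore shows only that the series gives no sign of the change behaving differently on these two cores; it does not show that the change carries over with a fixed size, and two pairs cannot establish a rule for the series or explain the result.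

The compounds shown leave open how the same exchange would behave on a third core, or in any assay other than this one. They also leave open what would follow if an amine took the place of the oxygen carrying the group, or if a longer chain replaced the saturated carbon on that oxygen.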